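Amide aryl variation: compound 2 to compound 4

This account rests on a few compounds, and the source may have more. Where it says the series, first, only, none or still open, it means among the compounds named here.

Measured so far in a functional assay on GTL 16 cells for antiproliferative activity against GTL 16 cell line (Homo sapiens), read by CCK-8 assay, with a stated time of 72 h; on this read-out lower numbers stand for stronger inhibition and higher numbers for weaker inhibition:
compound 1 `O=C(Nc1cccc(-c2oc3cc(-c4ccc(F)cc4)ccc3c(=O)c2O)c1)c1ccc(F)cc1` gives 14600 nM
compound 2 `Cc1ccccc1C(=O)Nc1cccc(-c2oc3cc(-c4ccc(F)cc4)ccc3c(=O)c2O)c1` gives 24800 nM
compound 3 `O=C(Nc1cccc(-c2oc3cc(-c4ccc(F)cc4)ccc3c(=O)c2O)c1)c1ccc(Br)cc1` gives 25400 nM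

Compound 2 stands second highest of these three numbers, yet it lies within the scatter of both compound 3 and compound 1, so no order among the three can be read. Compound 4 `Cc1cc(C)cc(C(=O)Nc2cccc(-c3oc4cc(-c5ccc(F)cc5)ccc4c(=O)c3O)c2)c1` is not yet measured. Its change from compound 2 is 3,5-dimethylphenyl in place of 2-methylphenyl on a carbonyl carbon. Two measured steps alter the same aryl on the carbonyl carbon: a 1.7-fold higher number from compound 1 to compound 2 (0.23 log units; within the scatter) and a 1.0-fold higher number from compound 2 to compound 3 (0.01 log units; within the scatter). Neither moved beyond the scatter, so for compound 4 no step beyond the scatter is expected in this assay, in either direction. The expected step is a 1.0-fold higher number from compound 2 to compound 4 (0.00 log units; within the scatter). Compound 4 is accordingly estimated at 25000 nM, with a range of 10000 nM to 60000 nM.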

Compound 4, half-maximal inhibitory concentration: 13500 nM
Compound 4: the middle estimate sits 1.9-fold (0.27 log units) above what was measured; low and high end bracket the measured number.
By their numbers in this assay, from the lowest: compounds 4, 1, 2 and 3 (each within the scatter of the next).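

In this assay the 3,5-dimethylphenyl group on this carbonyl carbon stays within the scatter of all three earlier aryl groups (a 1.8-fold lower number from compound 2 to compound 4 (0.26 log units; within the scatter); a 1.9-fold lower number from compound 3 to compound 4 (0.27 log units; within the scatter); a 1.1-fold lower number from compound 1 to compound 4 (0.03 log units; within the scatter)). Across compounds 1 to 4, neither two methyl groups on the aryl nor a single fluoro, bromo or methyl group separates the numbers, so all four aryl groups read alike at this position. No measured evidence explains this result. As far as these compounds go, it remains open whether replacing the aryl group with an amine-bearing chain, or adding a carboxylic acid to it, would move the number beyond the scatter.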